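Ring Size on the Amide Nitrogen and Maximal Response

The source may report more compounds than this note shows. Statements on the series, on what has been measured and on what is new or still open speak of the compounds shown alone.

Compound 2 `O=C(O)c1cc(-c2cccc(COc3ccc4c(c3)CN(C3CC3)C4=O)c2)ccc1Cl` stands lowest of the two measured compounds: in an assay on HEK293 cells for positive allosteric modulation of metabotropic glutamate receptor 2 (Rattus norvegicus), read by thallium flux (a lower number here means a smaller maximal response, a higher number a larger maximal response), compound 2 gives 64.9%. Within the data shown here, the only other measured compound, compound 1 `O=C(O)c1cc(-c2cccc(COc3ccc4c(c3)CN(c3ccccc3)C4=O)c2)ccc1Cl`, gives 86.2% in this assay. Among the measured compounds shown here, the two differ at a single place, and that difference forms the one measured step so far: a number 21.3 percentage points lower from compound 1 to compound 2 (beyond the scatter). Compound 3 `O=C(O)c1cc(-c2cccc(COc3ccc4c(c3)CN(C3CCCCC3)C4=O)c2)ccc1Cl` differs from compound 2 at the same place, as follows: cyclohexyl in place of cyclopropyl on an amide-type nitrogen in a ring. The measured step bears directly on this, since it shows that swapping a phenyl for a cyclopropyl at this nitrogen lowered the maximal response by a modest amount. Compound 3 carries a six-membered ring of carbon only in place of the three-membered one, so the maximal response is expected to recover part of the way, by a number 10.1 percentage points higher from compound 2 to compound 3 (beyond the scatter), a modest upward step. Compound 3 is estimated at 75%, within a range of 60% to 92%.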

Compound 3, largest response reached (Emax), in percent of the reference or control that the assay uses: 63.3%
Beside the measured number, compound 3's estimate is 11.7 percentage points above it; the measured number falls inside the stated range.
By their numbers in this assay, from the lowest: compounds 3 and 2 (each within the scatter of the next); then compound 1.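

Changing cyclopropyl to cyclohexyl on the amide-type nitrogen gives a number 1.6 percentage points lower from compound 2 to compound 3 (within the scatter), so in this assay these two rings of carbon only cannot be told apart, despite the difference in ring size. Changing phenyl to cyclohexyl gives a number 22.9 percentage points lower from compound 1 to compound 3 (beyond the scatter) in the same assay, so the loss first seen with cyclopropyl appears with a second non-aromatic ring, and compound 1, with its phenyl, stands above both. No measurement available here explains this pattern.

As far as these compounds go, it remains open whether the higher maximal response belongs to phenyl itself or would also appear with a pyridine ring or a benzyl group on this nitrogen. An open chain such as n-butyl, or a cyclopentyl ring, could also show whether the response stays level among non-aromatic groups.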